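The compounds below may be only part of what the source reports. "The series", "measured", "known", "first", "only" and "open" are said of these compounds alone.

Measured values in a functional assay on NCI-H460 cells (Homo sapiens) for inhibition, with a stated time of 72 h (a higher number here means a weaker inhibitor, a lower number a stronger inhibitor), stand as follows
Compound 1 `COc1ccc(S(=O)(=O)N2CCc3cccc(-c4ccc(F)c(F)c4)c32)cc1` gives 46 nM
Compound 2 `COc1ccc(S(=O)(=O)n2ccc3cccc(-c4ccc(C#N)cc4)c32)cc1` gives 172 nM

Compound 1 holds the lower of the two numbers, and compound 2 lies above it by more than the scatter. Among the measured compounds shown here, these two compounds differ in more than one place, so their values give no measured step for a single change. Compound 3 `COc1ccc(S(=O)(=O)N2CCc3cccc(-c4ccc(O)cc4)c32)cc1` is not yet measured. It keeps the core of compound 1 and differs from it as follows: 4-hydroxyphenyl in place of 3,4-difluorophenyl on an aromatic carbon.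

For the measured compounds named here, no measured step covers this exchange, so the expectation is weakly founded. Going by the values given here, it starts from compound 1 at 46 nM as the lowest number so far, from which a change is more likely to lead upward than downward. Compound 2 at 172 nM shows only how far the values reach so far. An expected step of a 2.6-fold higher number from compound 1 to compound 3 (0.42 log units; beyond the scatter) is estimated, toward a weaker inhibitor and modest in size. For compound 3 the estimated value is 120 nM (expected range 35 nM to 400 nM).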

Compound 3, half-maximal inhibitory concentration: 114 nM
Compound 3: the middle estimate sits 1.1-fold (0.02 log units) above what was measured; the measured number falls inside the stated range.
By their numbers in this assay, from the lowest: compound 1; then compounds 3 and 2 (each within the scatter of the next).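

In this assay, among the compounds shown here, the exchange of 3,4-difluorophenyl for 4-hydroxyphenyl on this aromatic carbon gives the only single-place step so far, a 2.5-fold higher number from compound 1 to compound 3 (0.39 log units; beyond the scatter), a modest move toward a weaker inhibitor. The position therefore accepts an aryl group carrying a hydrogen-bond donor and acceptor, and compound 3 remains an inhibitor at 114 nM in the same cellular read-out. The step combines the loss of both fluorines with the entry of the hydroxyl group, and no supporting measurement bears on its origin or on the share of either part.

Still open, on these data alone, is whether the step follows the fluorines or the hydroxyl group, a question that a phenyl ring carrying a single fluorine, a methoxy group or an amine at this place on the core of compound 1 could help to settle. Also open, as far as these compounds go, is how a phenyl ring bearing a nitrile would read on the core of compound 1, which would connect compound 2 to this pair through a single-place comparison.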